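Replacing the chloroacetyl group with ethyl on a urea nitrogen

The source may hold more compounds than are shown below. What is called first, only, known or untested is meant among the compounds shown, and "the series" means these compounds.

Three ureas have been tested in a functional assay on M21 cells (Homo sapiens) for antiproliferative activity, with a stated time of 48 h; on this read-out lower numbers stand for stronger inhibition and higher numbers for weaker inhibition. Compound 2 `CC(C)(C)c1ccc(CNC(=O)NC(=O)CCl)cc1` gives 2400 nM, the lowest of the three numbers; compound 3 `CCCCC(O)c1cccc(NC(=O)NC(=O)CCl)c1` gives 4600 nM, which lies within the scatter of compound 2, and compound 1 `CC(C)(C)c1ccc(CNC(=O)NCCCCl)cc1` gives 11000 nM. Among the measured compounds shown here, the one step among them, a 4.6-fold lower number from compound 1 to compound 2 (0.66 log units; beyond the scatter), changed the same nitrogen substituent that is now changed again. Compound 4 `CCNC(=O)NCc1ccc(C(C)(C)C)cc1` differs from compound 2 by ethyl in place of (chloromethyl)carbonyl on an amide-type nitrogen. For the measured compounds named here, no measured step removes the chlorine, so the single related step only hints at how sensitive this position is. The expectation is a weaker compound, with a 13-fold higher number from compound 2 to compound 4 (1.10 log units; beyond the scatter). Compound 4 is therefore estimated at 30000 nM, in a range from 8000 nM to 100000 nM.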

Compound 4, half-maximal inhibitory concentration: > 100000 nM
Compound 4: a limit, no number; the forecaster's own chance of this, stated with the estimate: 35%; middle value at least 3.3-fold (0.52 log units) from the limit.
By their numbers in this assay, from the lowest: compounds 2 and 3 (each within the scatter of the next); then compound 1. At a limit, above all of these: compound 4.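

Compound 4 gives > 100000 nM, which is a limit and not a number. With ethyl in place of (chloromethyl)carbonyl on this nitrogen, the result is an at least 41-fold higher number from compound 2 to compound 4 (1.61 log units; beyond the scatter), a far larger change than the earlier one at this position, a 4.6-fold lower number from compound 1 to compound 2 (0.66 log units; beyond the scatter). With hydrogen in place of chloromethyl on the chain, the result is an at least 9.0-fold higher number from compound 1 to compound 4 (0.95 log units; beyond the scatter), so both chlorine-bearing substituents, in compound 1 and compound 2, give measurable numbers, unlike ethyl.

Still open, going by these compounds, is whether the chlorine or the carbonyl counts for more. An acetyl group keeps the carbonyl without chlorine, and a 2-chloroethyl group keeps chlorine without the carbonyl.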